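A few compounds are considered here, and "the series" means these few. Any claim that something is new, unique, unknown or untested is made for them only; others in the source may bear on it.

Series notes. The shared core of compound 2 `CCCOc1cccc(C(=O)Nc2cccc(C(=O)O)c2)c1` is a benzamide carrying a carboxylic acid on the anilide ring and an alkoxy chain on the benzoyl ring. In an assay on isolated protein for agonist activity at Bile acid receptor (Homo sapiens), read by TR-FRET, with a stated time of 3 h, in the absence of a further agent (on this read-out higher numbers stand for an effect only at larger amounts of compound and lower numbers for an effect already at smaller amounts), compound 2 gives 2150 nM. For the measured compounds named here, that is the higher of the two numbers so far reported. Compound 3 `CC(C)COc1ccc(C(=O)Nc2cccc(C(=O)O)c2)cc1` carries an isobutoxy chain and differs from compound 2 in several places. In this assay compound 3 gives 357 nM. Compound 1 `O=C(O)COc1cccc(NC(=O)c2ccc(Oc3ccccc3)cc2)c1`, with a phenoxy group on the benzoyl ring and a oxyacetic acid in place of the benzoic acid, reaches only a limit of the assay, > 10000 nM; it sits at the limit of > 10000 nM in this assay, at which 1 of the 3 values shown sits, and supplies no number for comparison.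

Compound 4 `CC(C)CCOc1cccc(C(=O)Nc2cccc(C(=O)O)c2)c1` is not yet measured. It differs from compound 2 by isopropyl in place of methyl on a saturated chain carbon, two bonds along the chain from an oxygen on an aromatic ring, so the propoxy chain of compound 2 becomes an isopentyloxy chain in compound 4. Going by the values given here, no single-point step between measured compounds is on record, so the size of this change can only be expected, not read off. The direction is expected to be toward a lower number, as compound 3 with its branched chain gives 357 nM. For compound 4 the expected value in this assay is 900 nM, with a range from 300 nM to 2500 nM. The expected step of a 2.4-fold lower number from compound 2 to compound 4 (0.38 log units; beyond the scatter) would lie beyond the scatter.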

Compound 4, half-maximal effective concentration: 2760 nM
For compound 4 the middle estimate is 3.1-fold (0.49 log units) below the measured one; the whole stated range lies below it.
By their numbers in this assay, from the lowest: compound 3; then compounds 2 and 4 (each within the scatter of the next). At a limit, above all of these: compound 1.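

For the compounds shown here, at the place on a saturated chain carbon, two bonds along the chain from an oxygen on an aromatic ring, the series now has its only single-point step: in this assay, a 1.3-fold higher number from compound 2 to compound 4 (0.11 log units; within the scatter), and that step lies within the scatter. Propoxy and isopentyloxy chains therefore cannot be told apart on this read-out, so isopropyl in place of methyl at this place, with its larger heavy-atom count, leaves no readable mark on the number, a point that compound 3 could not settle as it differs from compound 2 in several places. Nothing on hand bears on why this change leaves the number within the scatter.

On these data alone, whether a longer unbranched chain such as hexyloxy, or an amine or a hydroxyl group at the end of the chain, would also stay within the scatter of compound 2 remains open. Going by these compounds alone, also open is whether isopropyl in place of methyl would give the same result on the core of compound 3, as no single-point pair connects that compound to the others.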